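The compounds below may be only part of what the source reports. "The series", "measured", "known", "first", "only" and "open" are said of these compounds alone.

Compound 1 `COc1cccc(-c2nn(-c3ccccc3)cc2-c2ccnc(NCCCNC(=O)c3cccc(C(F)(F)F)c3)c2)c1`: 1540 nM
Compound 2 `COc1cccc(-c2nn(-c3ccccc3)cc2-c2ccnc(NCCNC(=O)Nc3cccc(C(F)(F)F)c3)c2)c1`: 1730 nM

In a functional assay on SK-MEL-5 cells (Homo sapiens) for antiproliferative activity (a higher number here means a weaker inhibitor of growth, a lower number a stronger inhibitor of growth), compound 1 gives 1540 nM, and compound 2 gives 1730 nM; the two numbers lie within the scatter of each other, so neither stands apart. Compound 3 `COc1cccc(-c2nn(-c3ccccc3)cc2-c2ccnc(NCCCNC(=O)Nc3ccc(Cl)c(Cl)c3)c2)c1` differs from compound 1 by (3,4-dichlorophenyl)amino in place of 3-(trifluoromethyl)phenyl on a carbonyl carbon. For the measured compounds named here, no measured pair shows this change, so its effect is unknown. Given that compound 1 and compound 2 sit close together in this assay, the change is expected to move the number little, if at all, beyond the scatter. The expected step of a 1.0-fold lower number from compound 1 to compound 3 (0.01 log units; within the scatter) is small. Compound 3 is estimated at 1500 nM, with a range from 500 nM to 4500 nM.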

Compound 3, concentration for 50% growth inhibition: 1750 nM
Compound 3: middle estimate off by 1.2-fold (0.07 log units), on the low side; measured number inside the range.
By their numbers in this assay, from the lowest: compounds 1, 2 and 3 (each within the scatter of the next).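

In this assay, for the compounds shown here, the exchange of 3-(trifluoromethyl)phenyl for (3,4-dichlorophenyl)amino on a carbonyl carbon is the first one-place comparison available, and it stays within the scatter (a 1.1-fold higher number from compound 1 to compound 3 (0.06 log units; within the scatter)). At this position, then, the entering group's added hydrogen-bond donor and the altered ring substituents come with no readable difference in growth inhibition. Nothing measured here speaks to why the number holds.

Going by these compounds alone, the single step cannot separate the amino nitrogen from the change in ring substituents, as both change together. Going by these compounds, whether an amine, a carboxylic acid or a longer chain at this carbonyl carbon would be tolerated remains open.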